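A few compounds are considered here, and "the series" means these few. Any claim that something is new, unique, unknown or untested is made for them only; others in the source may bear on it.

Measured so far, in an ADME assay on HepG2 cells (Homo sapiens) for cytotoxicity, read by CellTiter-Glo and resazurin assay, with a stated time of 72 h; on this read-out lower numbers stand for an effect already at smaller amounts and higher numbers for an effect only at larger amounts of compound:
Compound 1 `CC(C)N(Cc1cccc(OCCCCCC(=O)O)c1)C(=O)c1ccc(-c2cccc(-c3ccccc3)c2)cc1` gives > 26000 nM.
Compound 2 `CCOc1cccc(-c2ccc(C(=O)N(Cc3cccc(OCCCCCC(=O)O)c3)C(C)C)cc2)c1` gives > 20800 nM.

Both of these values are limits of the assay rather than numbers. For compound 1 the value > 26000 nM is such a limit. For compound 2 the value > 20800 nM is likewise a limit, so compound 2 stands at the edge of what this assay reports, with no number of its own. For the measured compounds named here, the one measured step, a step that the two limits leave unreadable from compound 1 to compound 2, cannot be read because the limit of > 20800 nM in this assay, at which 1 of the 2 values shown sits, and the limit of > 26000 nM in this assay, at which 1 of the 2 values shown sits, mark both of its ends.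

Compound 3 `CC(C)N(Cc1cccc(OCCCCCC(=O)O)c1)C(=O)c1ccc(-c2cccc(S(C)(=O)=O)c2)cc1` has not yet been measured. It differs from compound 2 in one place: methylsulfonyl in place of ethoxy on an aromatic carbon. No readable step bears on this change, so no step beyond the scatter is expected in this assay in either direction. Compound 3 is therefore expected near 30000 nM, within 15000 nM to 60000 nM. The expected step is a step that the limit leaves unreadable from compound 2 to compound 3, none beyond the scatter. Most likely this assay will again report only a limit for compound 3.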

Compound 3, half-maximal effective concentration: > 26000 nM
Compound 3: no number, only a limit (the forecaster's own chance of this, stated with the estimate: 85%); the middle value lies beyond the limit too.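

For the compounds shown here, compound 1, compound 2 and compound 3 all give only limits in this assay, and no step among them can be read. The compounds shown leave open how far apart the three lie, and whether any group on this aromatic carbon gives an actual number in this assay.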